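Alpha-ketoamide series: secondary to tertiary amide step

A few compounds are considered here, and "the series" means these few. Any claim that something is new, unique, unknown or untested is made for them only; others in the source may bear on it.

Going by the values given here, compound 3 `CCNC(=O)C(=O)CCc1ccc(Cl)cc1` is the one member of the set with a numbered result: in an assay on HEK-293T cells for inhibition of phospholipase A and acyltransferase 4 (Homo sapiens), with stated times of 30 min and 20 min (a higher number here means a weaker inhibitor, a lower number a stronger inhibitor), compound 3 gives 3980 nM. Compound 1 `O=C(CCc1ccccc1)C(F)(F)C(=O)NCc1ccccc1` reaches only a limit in this assay, at > 10000 nM. Compound 2 `O=C(CCc1ccccc1)[C@H](F)C(=O)NCc1ccccc1` likewise returns a limit in this assay, at > 10000 nM. Compound 3 therefore stands alone as a number, alongside (the limit of > 10000 nM in this assay, at which 2 of the 3 values shown sit). Compound 4 `O=C(CCc1ccc(Cl)cc1)C(=O)N1CCCC1` carries pyrrolidin-1-yl in place of ethylamino on a carbonyl carbon, pyrrolidin-1-yl in place of ethylamino on a carbonyl carbon, and is not yet measured. Among the compounds with values here, no pair differing in one place has been measured, so no step size can be read from the data. A modest step toward weaker inhibition, near the edge of the scatter, is expected, giving an estimated step of a 1.5-fold higher number from compound 3 to compound 4 (0.18 log units; within the scatter). Compound 4 is expected in this assay at 6000 nM, with a range from 1500 nM to 20000 nM.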

Compound 4, half-maximal inhibitory concentration: > 10000 nM
Compound 4: no number, only a limit; the forecaster's own chance of this, stated with the estimate: 35%; middle value at least 1.6-fold (0.22 log units) from the limit.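

Going by these compounds alone, putting pyrrolidin-1-yl in place of ethylamino on a carbonyl carbon gives the only readable step, an at least 2.5-fold higher number from compound 3 to compound 4 (0.40 log units; beyond the scatter), in this assay. Because compound 4 returns only a limit, this step has a lower bound but no upper bound, and the series now sits mostly at that limit: the limit of > 10000 nM in this assay, at which 3 of the 4 values shown sit. The change removes the amide hydrogen and introduces the five-membered ring together, so the two cannot be separated here.

Diethylamino, which lacks the amide hydrogen but has no ring, would separate them. From the compounds shown here alone, whether any replacement for ethylamino gives a lower number than compound 3 also remains open.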